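From Compound 1 to Compound 4: A Furan Swap

A few compounds are considered here, and "the series" means these few. Any claim that something is new, unique, unknown or untested is made for them only; others in the source may bear on it.

Compound 1, `COc1ccc(/C=C/C(=O)c2ccc(OC)c3c2OC(C)(C)C=C3)c(F)c1`: > 10000 nM
Compound 2, `COc1ccc(C(=O)/C=C/c2ccc(N(c3ccccc3)c3ccccc3)cc2)c2c1C=CC(C)(C)O2`: > 10000 nM
Compound 3, `COc1ccc(C(=O)/C=C/c2ccc(OC)c(OC)c2OC)c2c1C=CC(C)(C)O2`: > 10000 nM

These three compounds were tested in a functional assay on K562 cells (Homo sapiens) for antiproliferative activity, read by MTT assay, with a stated time of 24 h; a higher number here means a weaker inhibitor, a lower number a stronger inhibitor. For compound 1 the value > 10000 nM is a limit of the assay, not a number. The value of compound 2 is likewise a limit. The value of compound 3 is likewise a limit. All three sit at the limit of > 10000 nM in this assay, at which 3 of the 3 values shown sit, so compound 1 stands with its companions rather than apart from them. Compound 4, `COc1ccc(C(=O)/C=C/c2ccco2)c2c1C=CC(C)(C)O2`, has not been measured; it differs from compound 1 by furan-2-yl in place of 2-fluoro-4-methoxyphenyl on a double-bonded chain carbon bound to a double-bonded chain carbon. Going by the values given here, with no measured step to lean on, no change beyond the scatter is expected, and the estimated step that the limit leaves unreadable from compound 1 to compound 4 reflects that. Compound 4 is expected to give 20000 nM, within 5000 nM to 80000 nM, most likely again reported only as a limit.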

Compound 4, half-maximal inhibitory concentration: > 10000 nM
Compound 4 gave a limit, no number; the forecaster's own chance of this, stated with the estimate: 80%; the middle value does not contradict the limit.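

Compound 1 and compound 4 each give only a limit, so no step can be read between them: the limit of > 10000 nM in this assay, at which 4 of the 4 values shown sit.

Which structure, if any, would give an actual number in this assay remains open.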